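Chloro to bromo on an anilino group at the assay limit

A few compounds are considered here, and "the series" means these few. Any claim that something is new, unique, unknown or untested is made for them only; others in the source may bear on it.

Two measured compounds share one core. Compound 1 `COc1ccccc1Nc1nc(-c2cccc(F)c2)nc2ccc(F)cc12` carries a 2-methoxyphenyl on the nitrogen on the aromatic ring, and in a functional assay on COLO 205 cells (Homo sapiens) for cytotoxicity, read by MTT assay, with a stated time of 48 h (on this read-out lower numbers stand for stronger inhibition and higher numbers for weaker inhibition), compound 1 gives > 50000 nM, which is a limit of the assay rather than a number. Compound 2 `Fc1cccc(-c2nc(Nc3cccc(Cl)c3)c3cc(F)ccc3n2)c1` carries a 3-chlorophenyl in that place; in this assay compound 2 gives > 50000 nM, again a limit and not a measured number. The step that the two limits leave unreadable from compound 1 to compound 2 therefore cannot be read, since the limit of > 50000 nM in this assay, at which 2 of the 2 values shown sit, shows both values resting at the same limit. Compound 2 thus stands at the limit, with nothing more known of its position.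

Compound 3 `Fc1cccc(-c2nc(Nc3ccc(Br)cc3)c3cc(F)ccc3n2)c1` differs from compound 2 by 4-bromophenyl in place of 3-chlorophenyl on a nitrogen on an aromatic ring. No measured step bears directly on this change: the only step shown is unreadable because the limit of > 50000 nM in this assay, at which 2 of the 2 values shown sit, places both of its ends at the limit. Exchanging one substituted phenyl for another gives no ground to expect a reading inside the measurable range, so the expected step of a number no higher from compound 2 to compound 3 (the limit leaves the size open) is estimated as none beyond the scatter. Compound 3 is therefore estimated at 50000 nM, with a range from 15000 nM to 200000 nM, and is most likely to be reported again as a limit.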

Compound 3, half-maximal inhibitory concentration: > 50000 nM
Compound 3 gave a limit, no number; the forecaster's own chance of this, stated with the estimate: 75%; the middle value sits exactly at the limit.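

In this assay compound 3 gives > 50000 nM, a limit of the assay and not a number. No new step can be read between compound 3 and either compound 1 or compound 2, because all three rest at one value: the limit of > 50000 nM in this assay, at which 3 of the 3 values shown sit. The compounds shown leave open whether any group on that nitrogen would bring a reading inside the measurable range.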